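The source may hold more compounds than are shown below. What is called first, only, known or untested is meant among the compounds shown, and "the series" means these compounds.

Measured compounds in a functional assay on a cell-free system (plasma, Oryctolagus cuniculus) for inhibition, with stated times of 5 min, 1 min and 6 min; on this read-out lower numbers stand for stronger inhibition and higher numbers for weaker inhibition:
compound 1 `CCOC(=O)c1c(C)nc(-c2cccc(C#N)c2)n1O`: 17600 nM
compound 2 `CCOC(=O)c1c(C)nc(-c2cccc(C#N)c2)n1OC`: 9130 nM
compound 3 `CCOC(=O)c1c(C)nc(-c2cccc(C#N)c2)n1OCCCO`: 11400 nM

Compound 1 holds the highest of the three numbers in this assay; its nearest neighbour is compound 3 a 1.5-fold lower number from compound 1 to compound 3 (0.19 log units; within the scatter) and its furthest is compound 2 a 1.9-fold lower number from compound 1 to compound 2 (0.29 log units; within the scatter). All three values lie within the scatter of one another, so no order among them can be read.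

Compound 4 `CCOC(=O)c1c(C)nc(-c2cccc(C#N)c2)n1OCc1cccc(Cl)c1` has not yet been measured. It differs from compound 1 by 3-chlorobenzyl in place of hydrogen on an oxygen on an aromatic ring. Within the data shown here, two measured steps bear on this change, both replacing the same hydrogen on the same oxygen: a 1.9-fold lower number from compound 1 to compound 2 (0.29 log units; within the scatter) and a 1.5-fold lower number from compound 1 to compound 3 (0.19 log units; within the scatter). Neither moved the number beyond the scatter. The entering group brings an aromatic ring of carbon only and a chlorine, features absent from both measured steps, so the range must be set wider than those steps alone would suggest. The expectation for compound 4 is therefore a number close to compound 1, possibly somewhat lower. The estimate for compound 4 in this assay is 10000 nM, between 3000 nM and 30000 nM. This corresponds to an expected step of a 1.8-fold lower number from compound 1 to compound 4 (0.25 log units; within the scatter).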

Compound 4, half-maximal inhibitory concentration: 19400 nM
Beside the measured number, compound 4's estimate is 1.9-fold (0.29 log units) below it, and the stated range covers the measured number.
By their numbers in this assay, from the lowest: compounds 2, 3, 1 and 4 (each within the scatter of the next, the first and the last beyond it).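

In this assay, 3-chlorobenzyl on the oxygen leaves the number level with the free hydroxy compound (a 1.1-fold higher number from compound 1 to compound 4 (0.04 log units; within the scatter)), so even this larger group, with its aromatic ring of carbon only and its chlorine, brings no gain in inhibition at this position. The comparison with the 3-hydroxypropyl ether also stays within the scatter (a 1.7-fold higher number from compound 3 to compound 4 (0.23 log units; within the scatter)). The methyl ether gives the only separation in the set, and a modest one (a 2.1-fold higher number from compound 2 to compound 4 (0.33 log units; beyond the scatter)), while compound 1 and compound 3 each lie within the scatter of both ends, so no trend with the size of the group can be claimed.

On these data alone, whether an amine or a carboxylic acid at the end of a longer chain on this oxygen would move the number beyond the scatter of compound 1 remains open. Nothing available explains these numbers.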